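This account rests on a few compounds, and the source may have more. Where it says the series, first, only, none or still open, it means among the compounds named here.

Working notes on the series in a functional assay for antagonist activity at transient receptor potential cation channel subfamily V member 1 (Homo sapiens), read by FLIPR and calcium flux; on this read-out higher numbers stand for weaker inhibition and lower numbers for stronger inhibition.

Compound 1 `O=C1COc2ccc(NC(=O)C3CCN(c4cccc(Br)c4)CC3)cc2N1` gives 330 nM in this assay. Compound 2 `O=C(Nc1cccc2[nH]ccc12)C1CCN(c2cccc(C(F)(F)F)c2)CC1` gives 230 nM in this assay; the two numbers lie within the scatter of each other, so compound 1 stands together with compound 2 rather than apart from it. Compound 3 `Cc1c(Cl)cccc1N1CCC(C(=O)Nc2ccc3c(c2)NC(=O)CO3)CC1` is not yet measured. It differs from compound 1 in one place: 3-chloro-2-methylphenyl in place of 3-bromophenyl on an amine nitrogen in a ring. Within the data shown here, since no measured pair shows a step of this kind, the expected change from compound 1 to compound 3 is small, a 1.3-fold lower number from compound 1 to compound 3 (0.12 log units; within the scatter), not beyond the scatter in either direction. For compound 3 the estimate in this assay is 250 nM, with a range from 90 nM to 700 nM.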

Compound 3, half-maximal inhibitory concentration: 100 nM
Beside the measured number, compound 3's estimate is 2.5-fold (0.40 log units) above it; the range from low to high includes it.
By their numbers in this assay, from the lowest: compound 3; then compounds 2 and 1 (each within the scatter of the next).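

At the aromatic group on the amine nitrogen in a ring, the step of a 3.3-fold lower number from compound 1 to compound 3 (0.52 log units; beyond the scatter) in this assay shows that this position can move the read-out beyond the scatter. The chlorine and the methyl of 3-chloro-2-methylphenyl enter together as 3-bromophenyl leaves, so the step belongs to the whole exchange and cannot be divided between them. No evidence at hand accounts for the step. On these data alone, whether the methyl alone carries the gain remains open. So does the outcome with a methoxy group or a nitrile on this phenyl ring.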